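A few compounds are considered here, and "the series" means these few. Any claim that something is new, unique, unknown or untested is made for them only; others in the source may bear on it.

Compound 1 `Oc1cccc(-c2cc(-c3ccc(C(F)(F)F)cc3)cc(-c3ccccc3O)n2)c1` and compound 2 `Oc1cccc(-c2cc(-c3ccc(C(F)(F)F)cc3)cc(-c3cccc(O)c3)n2)c1` share a core and differ only in one group. In a functional assay on T47D cells (Homo sapiens) for inhibition (on this read-out higher numbers stand for weaker inhibition and lower numbers for stronger inhibition), compound 1 reaches only a limit of the assay, > 50000 nM. In this assay compound 2 gives 2330 nM. The change between them is 3-hydroxyphenyl in place of 2-hydroxyphenyl on an aromatic carbon and it produces an at least 21-fold lower number from compound 1 to compound 2 (1.33 log units; beyond the scatter); the true size of this step is not fixed, since compound 1 sits at the limit of > 50000 nM in this assay, at which 1 of the 3 values shown sits. Compound 3 `Oc1cccc(-c2cc(-c3cccc(OC(F)(F)F)c3)cc(-c3ccccc3O)n2)c1` carries a different core, and how its core differs from that of compound 1 is not broken down here. In this assay compound 3 gives 5390 nM. Compound 4 `Oc1cccc(-c2cc(-c3cccc(OC(F)(F)F)c3)cc(-c3cccc(O)c3)n2)c1` is not yet measured and differs from compound 3 by 3-hydroxyphenyl in place of 2-hydroxyphenyl on an aromatic carbon. This is the same kind of change as that from compound 1 to compound 2, but the surroundings are not identical: in compound 1 the place is meta to a 4-(trifluoromethyl)phenyl group, whereas in compound 3 it is meta to a large group. Because the earlier step was an at least 21-fold lower number from compound 1 to compound 2 (1.33 log units; beyond the scatter), compound 4 is expected to show a gain of an 11-fold lower number from compound 3 to compound 4 (1.03 log units; beyond the scatter) in this assay. Compound 4 is therefore estimated at 500 nM, within 100 nM to 2500 nM.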

Compound 4, half-maximal inhibitory concentration: 6740 nM
Compound 4: middle estimate off by 13-fold (1.13 log units), on the low side; the whole stated range lies below it.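

In this assay, 3-hydroxyphenyl in place of 2-hydroxyphenyl gives a 1.3-fold higher number from compound 3 to compound 4 (0.10 log units; within the scatter), so the large step seen on the core of compound 1 does not carry over to the core of compound 3, and the two steps differ: the same change on two cores in this assay, an at least 21-fold lower number (1.33 log units; beyond the scatter) from compound 1 to compound 2 and a 1.3-fold higher number (0.10 log units; within the scatter) from compound 3 to compound 4, at least 26-fold (1.42 log units) apart, beyond the scatter of two such steps. Compound 1 stands at a limit of the assay, so the earlier step has no fixed size and the gap between the two steps has no fixed size either: the limit of > 50000 nM in this assay, at which 1 of the 4 values shown sits. Within the data shown here, with only two cores, the data do not show which of the two outcomes is typical for this change, nor why the outcomes differ.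

The compounds shown leave open whether the change would again give a large step on cores with other groups in place of the 4-(trifluoromethyl)phenyl group, such as a plain phenyl or a 4-chlorophenyl. They also leave open how an amine or a carboxylic acid in place of the hydroxyl of the 3-hydroxyphenyl group would read out.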